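Halogenated phenyl replaces trifluoromethylphenyl on the shared core

The source may report more compounds than this note shows. Statements on the series, on what has been measured and on what is new or still open speak of the compounds shown alone.

Going by the values given here, compound 3 `COc1nc(-c2ccc(C(F)(F)F)cc2)ccc1[C@@H](c1ccccc1)[C@@](O)(CCN(C)C)c1cccc2ccccc12` is one of three compounds measured in a toxicity assay on HeLa cells (Homo sapiens) for cytotoxicity; on this read-out lower numbers stand for higher toxicity in this test and higher numbers for lower toxicity in this test. Its result is a limit of the assay rather than a number: in this assay compound 3 gives > 64 ug/mL. Compound 3 thus stands at the limit of > 64 ug/mL in this assay, at which 1 of the 3 values shown sits. The related compound 2 `COc1nc(C2CCCCC2)ccc1[C@@H](c1ccccc1)[C@@](O)(CCN(C)C)c1cccc2ccccc12` gives 57.7 ug/mL in this assay, while compound 1 `COc1nc(-c2cccc(Cl)c2)ccc1[C@@H](c1ccccc1)[C@@](O)(CCN(C)C)c1cccc2ccccc12` has no result reported, "nd" (no result reported). Among the compounds with values here, the only measured step that bears on the change considered here, an at least 1.1-fold higher number from compound 2 to compound 3 (0.04 log units; that floor lies within the scatter), is merely a floor and shows no shift beyond the scatter. Compound 4 `COc1nc(-c2ccc(Cl)c(F)c2)ccc1[C@@H](c1ccccc1)[C@@](O)(CCN(C)C)c1cccc2ccccc12` differs from compound 3 by 4-chloro-3-fluorophenyl in place of 4-(trifluoromethyl)phenyl on an aromatic carbon. The expectation for compound 4 rests on compound 2 at 57.7 ug/mL and on the step of an at least 1.1-fold higher number from compound 2 to compound 3 (0.04 log units; that floor lies within the scatter), both pointing to weak toxicity with this core. Compound 4 is therefore expected to show an at least 1.0-fold lower number from compound 3 to compound 4 (0.02 log units; that floor lies within the scatter), nothing beyond the scatter. The estimate for compound 4 in this assay is 60 ug/mL, within a range from 25 ug/mL to 110 ug/mL, with a fair chance that only a limit is reported again.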

Compound 4, half-maximal cytotoxic concentration: > 64 ug/mL
Compound 4 ended at the assay's limit; the forecaster's own chance of this, stated with the estimate: 50%; middle value at least 1.0-fold (0.02 log units) from the limit.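

In this assay, the step from compound 3 to compound 4 cannot be read, as both compounds end at a limit of the assay. What compound 4 adds is a second aromatic group at this position, 4-chloro-3-fluorophenyl, which compares with the cyclohexyl of compound 2 as an at least 1.1-fold higher number from compound 2 to compound 4 (0.04 log units; that floor lies within the scatter), so this comparison too gives only a floor and shows no shift beyond the scatter. Exchanging 4-(trifluoromethyl)phenyl for this halogenated phenyl leaves the reading where it was: the limit of > 64 ug/mL in this assay, at which 2 of the 4 values shown sit.

As far as these compounds go, the true size of the difference between compound 3 and compound 4 stays open, and compound 1 adds nothing because it has no result reported. Also open, from the compounds shown here alone, is whether an amine or a carboxylic acid on the phenyl ring, or a longer chain in its place, would give a number that can be read in this assay.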